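Compound 3 loses its bromines: what compound 4 may show

A few compounds are considered here, and "the series" means these few. Any claim that something is new, unique, unknown or untested is made for them only; others in the source may bear on it.

In a functional assay on HepG2 cells (Homo sapiens) for cytotoxicity, read by MTT assay, with a stated time of 72 h (on this read-out lower numbers stand for stronger inhibition and higher numbers for weaker inhibition), compound 1 `O=C(N/N=C/c1ccc([N+](=O)[O-])cc1)Nc1cc2c(Nc3ccc(F)c(Cl)c3)ncnc2cc1O[C@H]1CCOC1` reads 35300 nM while compound 2 `COc1ccc(/C=N/NC(=O)Nc2cc3c(Nc4ccc(F)c(Cl)c4)ncnc3cc2O[C@H]2CCOC2)c(OC)c1OC` reads 29300 nM (the step is a 1.2-fold lower number from compound 1 to compound 2 (0.08 log units; within the scatter)). Compound 3 `O=C(N/N=C/c1cc(Br)c(O)c(Br)c1)Nc1cc2c(Nc3ccc(F)c(Cl)c3)ncnc2cc1O[C@H]1CCOC1` stands at 2740 nM as the lowest of the three numbers, and its steps to both others lie beyond the scatter. Compound 4 `O=C(N/N=C/c1ccc(O)cc1)Nc1cc2c(Nc3ccc(F)c(Cl)c3)ncnc2cc1O[C@H]1CCOC1` has not yet been measured. It carries 4-hydroxyphenyl in place of 3,5-dibromo-4-hydroxyphenyl on a carbon with a double bond to nitrogen.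

Among the measured compounds shown here, two measured steps bear on this change, and both are large (a 13-fold lower number from compound 1 to compound 3 (1.11 log units; beyond the scatter) and an 11-fold lower number from compound 2 to compound 3 (1.03 log units; beyond the scatter)). Each of them arrives at the 3,5-dibromo-4-hydroxyphenyl group from another group. For the measured compounds named here, no measured compound carries 4-hydroxyphenyl, so the data cannot separate the bromines from the hydroxy group. Leaving the dibromo group is therefore expected to give a higher number, though perhaps not one that returns fully to the level of compound 1 and compound 2. The expected move is a 5.5-fold higher number from compound 3 to compound 4 (0.74 log units; beyond the scatter) and it is only an estimate. In this assay the estimated value for compound 4 is 15000 nM (expected range 5000 nM to 40000 nM).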

Compound 4, half-maximal inhibitory concentration: 70 nM
Compound 4: middle estimate off by 210-fold (2.33 log units), on the high side; measured number below the stated range.
By their numbers in this assay, from the lowest: compound 4; then compound 3; then compounds 2 and 1 (each within the scatter of the next).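

In this assay, taking the bromines off the 3,5-dibromo-4-hydroxyphenyl group did not raise the number but lowered it sharply, a 39-fold lower number from compound 3 to compound 4 (1.59 log units; beyond the scatter), so the dibromo group is not what gives the low numbers on this carbon with a double bond to nitrogen. The unsubstituted-looking contrast is wider still against the two other groups, a 420-fold lower number from compound 2 to compound 4 (2.62 log units; beyond the scatter) and a 500-fold lower number from compound 1 to compound 4 (2.70 log units; beyond the scatter), which shows that this one place can move the read-out far more than the first three compounds suggested and makes compound 4 the most potent of the four. Since compound 3 and compound 4 both carry the hydroxy group and differ only in the bromines, the bromines in compound 3 are tied to a weaker number than the hydroxy group gives alone, but no measurement at hand explains why.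

The compounds shown leave open whether the hydroxy group itself is needed, since a plain phenyl group or a 4-aminophenyl group at the same place would test that directly. They also leave open whether a single bromine on the 4-hydroxyphenyl group would give a number lying between those of compound 4 and compound 3.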